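Swapping a Benzyl Substituent and Cytotoxicity in Skin Cells

The source may report more compounds than this note shows. Statements on the series, on what has been measured and on what is new or still open speak of the compounds shown alone.

Compound 2 `Cc1cc(S(=O)(=O)/N=C(\N)n2nccc2-c2ccccc2)c(SCc2ccccc2C)cc1Cl` is one of two compounds already tested. In an ADME assay on HaCaT cells (Homo sapiens) for cytotoxicity, read by MTT assay, with a stated time of 72 h (a higher number here means a weaker inhibitor, a lower number a stronger inhibitor), compound 2 gives 18000 nM, and compound 1 `Cc1cc(-c2ccccc2)n(/C(N)=N/S(=O)(=O)c2cc(C)c(Cl)cc2SCc2ccc(C(F)(F)F)cc2)n1` gives 18000 nM in this assay, so compound 2 stands level with compound 1 within the scatter. Compound 3 `Cc1cc(S(=O)(=O)/N=C(\N)n2nccc2-c2ccccc2)c(SCc2ccc(Cl)cc2)cc1Cl` has not yet been measured; it differs from compound 2 by 4-chlorophenyl in place of 2-methylphenyl on a saturated chain carbon bound to a sulfur. For the measured compounds named here, no comparable pair of measured compounds exists, and the two measured compounds sit at the same level, so no step beyond the scatter is expected in this assay. The expected step is no change at the digits printed from compound 2 to compound 3 (within the scatter). Compound 3 is estimated at 18000 nM, between 9000 nM and 36000 nM.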

Compound 3, half-maximal inhibitory concentration: 12000 nM
Estimate against measurement, compound 3: 1.5-fold (0.18 log units) above; low and high end bracket the measured number.
By their numbers in this assay, from the lowest: compounds 3, 1 and 2 (each within the scatter of the next).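

In this assay the swap of 2-methylphenyl for 4-chlorophenyl on a saturated chain carbon bound to a sulfur gives a 1.5-fold lower number from compound 2 to compound 3 (0.18 log units; within the scatter) and so stays within the usual scatter of repeated measurements. For the compounds shown here, this is the first step read at this position, and it shows that this exchange of one substituted ring for another leaves the read-out effectively unmoved. Nothing measured here speaks to why. Still open, going by these compounds, is whether an amine or a carboxylic acid in this place would give a step beyond the scatter.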